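A few compounds are considered here, and "the series" means these few. Any claim that something is new, unique, unknown or untested is made for them only; others in the source may bear on it.

Compound 3 `CN1CCN(c2cccc3c2C[C@H](CN(C)[C@H]2CCCc4cccnc42)N(C)C3)CC1` gives 364 nm/s in an ADME assay for permeability, using PAMPA, at pH 7.4 (on this read-out higher numbers stand for higher permeability and lower numbers for lower permeability), the highest of the three numbers at hand. Compound 2 `CCN1CCN(c2cccc3c2C[C@H](CN(C)[C@H]2CCCc4cccnc42)NC3)CC1` gives 205 nm/s, which lies within the scatter of compound 3, while compound 1 `C[C@@H]1CN(c2cccc3c2C[C@H](CN(C)[C@H]2CCCc4cccnc42)NC3)C[C@H](C)N1` gives 39 nm/s, beyond the scatter below it. Among the compounds with values here, the one single-point step measured here is a 5.3-fold higher number from compound 1 to compound 2 (0.72 log units; beyond the scatter), which concerns the group on the aromatic carbon and does not touch the ring amine.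

Compound 4 `CN1CCN(c2cccc3c2C[C@H](CN(C)[C@H]2CCCc4cccnc42)NC3)CC1` differs from compound 3 by hydrogen in place of methyl on an amine nitrogen in a ring. Within the data shown here, no measured step covers this change alone, because compound 2 and compound 3 differ in two places at once. What their two values show is that compound 2, which also bears hydrogen at that ring nitrogen, sits somewhat lower than compound 3, though within the scatter. Compound 4 is therefore expected to sit near compound 2, with the step of a 1.8-fold lower number from compound 3 to compound 4 (0.26 log units; within the scatter) expected to be small and at the edge of the scatter. The estimate for compound 4 is 200 nm/s, with a range from 90 nm/s to 400 nm/s.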

Compound 4, apparent permeability: 996 nm/s
Compound 4: middle estimate off by 5.0-fold (0.70 log units), on the low side, and the stated range ends below it.
By their numbers in this assay, from the lowest: compound 1; then compounds 2 and 3 (each within the scatter of the next); then compound 4.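

Within the data shown here, the ring nitrogen proves to be a position that moves this read-out: in this assay, hydrogen in place of methyl on that amine nitrogen gives a 2.7-fold higher number from compound 3 to compound 4 (0.44 log units; beyond the scatter), a step beyond the scatter that no earlier pair could isolate. The group on the aromatic carbon also matters at the level of a single methyl, since replacing the terminal methyl with hydrogen on the saturated chain carbon gives a 4.9-fold higher number from compound 2 to compound 4 (0.69 log units; beyond the scatter), while 4-methylpiperazin-1-yl in place of 3,5-dimethylpiperazin-1-yl gives the largest step, a 26-fold higher number from compound 1 to compound 4 (1.41 log units; beyond the scatter). No measurement at hand accounts for any of these steps.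

Among these compounds, the ring nitrogen step is seen only with 4-methylpiperazin-1-yl on the aromatic carbon, so whether it holds with other groups there remains open. The compounds shown also leave open how an ethyl or acetyl group on that ring nitrogen would read.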